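Three Sulfonamides at the Limit, a Fourth Awaits Measurement

This account rests on a few compounds, and the source may have more. Where it says the series, first, only, none or still open, it means among the compounds named here.

Compound 1, `COc1cccc(N2C(=O)COc3ccc(-c4cnc(Cl)c(NS(=O)(=O)c5ccc(F)cc5)c4)cc32)c1`, in a functional assay on HepG2 cells (Homo sapiens) for antiproliferative activity, read by MTT assay, with a stated time of 72 h (a lower number here means a stronger inhibitor, a higher number a weaker inhibitor), gives > 40000 nM, which is a limit of the assay rather than a number.
Compound 2, `O=C1COc2ccc(-c3cccc(NS(=O)(=O)c4ccc(F)cc4)c3)cc2N1`, in this assay gives > 40000 nM, again a limit of the assay.
Compound 3, `O=C1COc2ccc(-c3cnc(Cl)c(NS(=O)(=O)c4ccc(F)cc4)c3)cc2N1`, in this assay gives > 40000 nM, also a limit.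

All three measured compounds therefore sit at the limit of > 40000 nM in this assay, at which 3 of the 3 values shown sit. The change from compound 3 to compound 1 is 3-methoxyphenyl in place of hydrogen on an amide-type nitrogen in a ring. Its step that the two limits leave unreadable from compound 3 to compound 1 cannot be read, since both ends are limits. How the core of compound 2 differs from that of compound 3 is not broken down here.

Compound 4, `COc1cccc(N2C(=O)COc3ccc(-c4cccc(NS(=O)(=O)c5ccc(F)cc5)c4)cc32)c1`, has not yet been measured. It differs from compound 2 by 3-methoxyphenyl in place of hydrogen on an amide-type nitrogen in a ring, the same change that was made from compound 3 to compound 1, at the same place. In this assay the step that the limit leaves unreadable from compound 2 to compound 4 is expected to stay unreadable, because compound 3 and compound 1 both rest at the limit of > 40000 nM in this assay, at which 3 of the 3 values shown sit, and compound 2 rests there too. Compound 4 is accordingly expected to give an estimated 60000 nM, with a range of 15000 nM to 200000 nM, most likely reported as a limit once more.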

Compound 4, half-maximal inhibitory concentration: > 40000 nM
Compound 4 was reported as a limit; the forecaster's own chance of this, stated with the estimate: 85%; the middle value is on the limit's open side.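

Compound 4, like compound 2, is reported only as a limit of the assay, so the step between them cannot be read and the result yields no new step: the limit of > 40000 nM in this assay, at which 4 of the 4 values shown sit.

The compounds shown leave open what 3-methoxyphenyl in place of hydrogen on an amide-type nitrogen in a ring does in this assay when the values are not limits.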